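The source may report more compounds than this note shows. Statements on the series, on what has been measured and on what is new or still open speak of the compounds shown alone.

Measured compounds in an ADME assay on NIH3T3 cells (Mus musculus) for cytotoxicity, read by XTT assay, with a stated time of 24 h; on this read-out lower numbers stand for stronger inhibition and higher numbers for weaker inhibition:
- compound 1 `Cn1nnnc1SCC(=O)N/N=C/c1ccc([N+](=O)[O-])cc1`: 9300000 nM
- compound 2 `Cc1ccc(/C=N/NC(=O)CSc2nnnn2C)cc1`: 3160000 nM
- compound 3 `Cn1nnnc1SCC(=O)N/N=C/c1ccc(F)cc1`: 10000000 nM

Compound 1 holds the second highest of the three numbers; compound 3 sits within the scatter of it, compound 2 gives the lowest number of the set. The unmeasured compound 4 `Cn1nnnc1SCC(=O)N/N=C/c1ccc(Br)cc1` differs from compound 1 in one place: bromo in place of nitro on an aromatic carbon, on an aromatic carbon para to a large group. For the measured compounds named here, two measured steps bear on this change. Replacing nitro by another halogen, fluoro, gave a 1.1-fold higher number from compound 1 to compound 3 (0.03 log units; within the scatter), so no shift beyond the scatter; replacing it by methyl gave a 2.9-fold lower number from compound 1 to compound 2 (0.47 log units; beyond the scatter). A halogen for nitro is the closer precedent, so in this assay the change is expected to give a 1.3-fold lower number from compound 1 to compound 4 (0.12 log units; within the scatter). Compound 4 is therefore estimated at 7000000 nM, with a range from 3000000 nM to 15000000 nM.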

Compound 4, half-maximal inhibitory concentration: 10000000 nM
Compound 4: middle estimate off by 1.4-fold (0.15 log units), on the low side; the measured number falls inside the stated range.
By their numbers in this assay, from the lowest: compound 2; then compounds 1, 3 and 4 (each within the scatter of the next).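

In this assay, a second halogen on this aromatic carbon para to a large group gives no separation from nitro or fluoro (a 1.1-fold higher number from compound 1 to compound 4 (0.03 log units; within the scatter); no change at the digits printed from compound 3 to compound 4 (within the scatter)), so compounds 1, 3 and 4 cannot be told apart. Methyl alone stands apart among the four substituents (a 3.2-fold higher number from compound 2 to compound 4 (0.50 log units; beyond the scatter)). Nothing available bears on the cause of these differences or their absence.

Going by these compounds, whether an amine or a carboxylic acid at this position would stay with the halogens or depart from them remains open. Also open, on these data alone, is whether changes elsewhere on the shared core would shift the values.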